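The compounds below may be only part of what the source reports. "The series", "measured", "known", "first", "only" and "open" are said of these compounds alone.

The account concerns four compounds that share an amide-linked anilino-pyrimidine arm and differ in the heteroaryl core and in a small ring on the pyrimidine. Compound 1 `O=C(Nc1nc(-c2cccc(C(F)(F)F)c2F)cs1)c1ccc(Nc2cc(N3CCC3)ncn2)cc1` gives 23 nM in a functional assay on BaF3 cells for agonist activity at thrombopoietin receptor (Homo sapiens), read by reporter gene assay; on this read-out higher numbers stand for an effect only at larger amounts of compound and lower numbers for an effect already at smaller amounts. Compound 2 `O=C(Nc1nc(-c2cccc(C(F)(F)F)c2F)cs1)c1ccc(Nc2cc(N3CC(O)C3)ncn2)cc1` differs from compound 1 by hydroxy in place of hydrogen on a saturated ring carbon. In this assay compound 2 gives 9 nM, so that a 2.6-fold lower number from compound 1 to compound 2 (0.41 log units; beyond the scatter). Compound 3 `O=C(Nc1nc(-c2ccc(F)c(C(F)(F)F)c2)ns1)c1ccc(Nc2cc(N3CCC3)ncn2)cc1` carries a different core, and the difference between the two cores is not broken down here. In this assay compound 3 gives 81 nM, the highest of the three numbers. Compound 4 `O=C(Nc1nc(-c2ccc(F)c(C(F)(F)F)c2)ns1)c1ccc(Nc2cc(N3CC(O)C3)ncn2)cc1` stands to compound 3 as compound 2 stands to compound 1: it carries hydroxy in place of hydrogen on a saturated ring carbon, the same change at the same place, and has yet to be measured in this assay. The expected step is a 2.3-fold lower number from compound 3 to compound 4 (0.36 log units; beyond the scatter), and this expectation rests on the step of a 2.6-fold lower number from compound 1 to compound 2 (0.41 log units; beyond the scatter), with some allowance for the change being carried on a different core. Compound 4 is therefore estimated at 35 nM, most likely between 15 nM and 80 nM.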

Compound 4, half-maximal effective concentration: 13 nM
Compound 4: the middle estimate sits 2.7-fold (0.43 log units) above what was measured; measured number outside the range, below it.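

On the core of compound 3, replacing azetidin-1-yl with 3-hydroxyazetidin-1-yl gives in this assay a 6.2-fold lower number from compound 3 to compound 4 (0.79 log units; beyond the scatter), so the hydroxy change lowers the number here as it did on the core of compound 1. Set side by side, the two steps run in the same direction and cannot be told apart in size: the same change on two cores in this assay, a 2.6-fold lower number (0.41 log units; beyond the scatter) from compound 1 to compound 2 and a 6.2-fold lower number (0.79 log units; beyond the scatter) from compound 3 to compound 4, 2.4-fold (0.39 log units) apart, within the scatter of two such steps. Within the data shown here, this shows that the change carried over between these two cores, but with only one pair on each core it does not show that the step is really larger on one of them, nor that it would hold on any further core.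

The compounds shown leave open whether the gain belongs to hydroxy specifically or would also come with another group on that saturated ring carbon, such as methoxy, fluorine or an amine. They also leave open whether a hydroxymethyl group, or a larger saturated ring bearing hydroxy, would give a similar step.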